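Acetyl for Allyl on the Xanthine Side Chain

The source may report more compounds than this note shows. Statements on the series, on what has been measured and on what is new or still open speak of the compounds shown alone.

Of the compounds shown here, three sharing one core have been measured in a functional assay (trachea) with Cavia porcellus as the target; a higher number here means that more compound is needed for the effect, a lower number that less compound is needed. Compound 1 `CCCn1c(=O)n(CC)c(=O)c2[nH]cnc21` gives 1300 nM, compound 2 `C=CCCn1c(=O)c2[nH]cnc2n(CCC)c1=O` gives 200 nM, and compound 3 `CCCn1c(=O)n(CCC#N)c(=O)c2[nH]cnc21` gives 1700 nM. Among these, compound 2 stands with the lowest number: the step of a 6.5-fold lower number from compound 1 to compound 2 (0.81 log units; beyond the scatter) lies beyond the scatter, as does the step of an 8.5-fold higher number from compound 2 to compound 3 (0.93 log units; beyond the scatter), while the step of a 1.3-fold higher number from compound 1 to compound 3 (0.12 log units; within the scatter) stays within it.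

Compound 4 `CCCn1c(=O)n(CC(C)=O)c(=O)c2[nH]cnc21` differs from compound 2 by acetyl in place of allyl on a saturated chain carbon bound to an aromatic nitrogen. Two measured steps speak to this change. The step of an 8.5-fold higher number from compound 2 to compound 3 (0.93 log units; beyond the scatter) shows that exchanging the vinyl for a cyano, a group carrying an acceptor, costs a modest amount, and the step of a 6.5-fold lower number from compound 1 to compound 2 (0.81 log units; beyond the scatter) shows that the vinyl itself accounts for the low number of compound 2. Removing the vinyl and bringing in a carbonyl oxygen acceptor instead is therefore expected to push the number back up toward the region of compound 1 and compound 3, with a step of a 7.5-fold higher number from compound 2 to compound 4 (0.88 log units; beyond the scatter) in this assay.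

Compound 4 is accordingly estimated at 1500 nM in this assay, with a range from 400 nM to 5000 nM.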

Compound 4, half-maximal effective concentration: 14900 nM
Estimate against measurement, compound 4: 9.9-fold (1.00 log units) below; measured number outside the range, above it.
By their numbers in this assay, from the lowest: compound 2; then compounds 1 and 3 (each within the scatter of the next); then compound 4.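

In this assay, compound 1 and compound 3 stayed within the scatter of each other, which left open whether the number at this position could rise beyond theirs, and the acetyl group shows that it can, with an 11-fold higher number from compound 1 to compound 4 (1.06 log units; beyond the scatter) and an 8.8-fold higher number from compound 3 to compound 4 (0.94 log units; beyond the scatter). The exchange of allyl for acetyl on a saturated chain carbon bound to an aromatic nitrogen gives a 75-fold higher number from compound 2 to compound 4 (1.87 log units; beyond the scatter), the largest step among these compounds, although both groups have the same count of heavy atoms and each has a double bond outside aromatic rings. The position therefore distinguishes sharply between two groups that differ, in what is counted, by oxygen in place of carbon and by the hydrogen-bond acceptor that enters with it.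

Compounds with a 2-hydroxypropyl or 2-methoxyethyl group at this place would help show whether the high number follows the carbonyl or oxygen in the chain more generally. No measurement shown here accounts for the size of these steps.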